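Three Limits and a Fourth Aryl Group

The source may report more compounds than this note shows. Statements on the series, on what has been measured and on what is new or still open speak of the compounds shown alone.

Compound 1, `OC[C@H]1O[C@@H](n2cnc3c(NCc4ccc(F)cc4F)ncnc32)[C@H](O)[C@@H]1O`: in a functional assay on HOS cells (Homo sapiens) for antiproliferative activity, with a stated time of 72 h (on this read-out lower numbers stand for stronger inhibition and higher numbers for weaker inhibition), compound 1 gives > 166000 nM, which is a limit of the assay and not a number.
Compound 2, `OC[C@H]1O[C@@H](n2cnc3c(NCc4ccc(F)c(Cl)c4)ncnc32)[C@H](O)[C@@H]1O`: in this assay compound 2 gives > 166000 nM, again a limit of the assay.
Compound 3, `Cc1ccc(O)c(CNc2ncnc3c2ncn3[C@@H]2O[C@H](CO)[C@@H](O)[C@H]2O)c1`: in this assay compound 3 gives > 166000 nM, once more a limit of the assay.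

Compound 3 therefore stands at the same limit as every other value shown, namely (the limit of > 166000 nM in this assay, at which 3 of the 3 values shown sit). The three measured steps among these compounds, a step that the two limits leave unreadable from compound 1 to compound 2, a step that the two limits leave unreadable from compound 1 to compound 3 and a step that the two limits leave unreadable from compound 2 to compound 3, cannot be read in size or direction, since each joins two limits.

Compound 4, `OC[C@H]1O[C@@H](n2cnc3c(NCc4ccc(C(F)(F)F)cc4)ncnc32)[C@H](O)[C@@H]1O`, has not yet been measured. It differs from compound 3 in one place: 4-(trifluoromethyl)phenyl in place of 2-hydroxy-5-methylphenyl on a saturated chain carbon bound to a nitrogen on an aromatic ring. The measured steps bear on this change only in so far as every aryl variation shown has left the value at the limit; none of them reveals a movement beyond the scatter. The step that the limit leaves unreadable from compound 3 to compound 4 is accordingly expected to show no readable change. For compound 4 the expected value in this assay is 200000 nM, with a range from 60000 nM to 600000 nM, and a reported limit rather than a number is the more likely outcome.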

Compound 4, half-maximal inhibitory concentration: > 166000 nM
Compound 4: a limit, no number; the forecaster's own chance of this, stated with the estimate: 85%; the middle value is on the limit's open side.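

Each step joining compound 4 to compound 1, compound 2 or compound 3 links two limits of the assay, and none can be read in size or direction. The compounds shown leave open whether any aryl group on the shared core would give a number in this assay.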